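Swapping One Pyrazole for a Smaller One

The compounds below may be only part of what the source reports. "The series", "measured", "known", "first", "only" and "open" are said of these compounds alone.

Three compounds share the same core and differ only in the five-membered ring attached to it. In an in vitro assay on HEK293 cells for displacement of a labelled ligand from adenosine receptor A2b (Homo sapiens) (on this read-out lower numbers stand for stronger inhibition and higher numbers for weaker inhibition), compound 1 `CCCn1c(=O)c2nc(-c3cc(C)nn3CC)[nH]c2n(CCC)c1=O` gives 2100 nM, the highest of the three numbers. Compound 2 `CCCn1c(=O)c2nc(-c3cnn(Cc4c(F)cccc4F)c3)[nH]c2n(CCC)c1=O` gives 390 nM in this assay, and compound 3 `CCn1c(=O)c2nc(-c3cnn(Cc4ccccc4)c3)[nH]c2n(CC)c1=O` gives 19 nM; both gaps from compound 1 lie beyond the usual scatter, so compound 1 is the weakest binder of the three measured. Compound 4 `CCCn1c(=O)c2nc(-n3cccn3)[nH]c2n(CCC)c1=O` has not yet been measured. It differs from compound 1 in one place: 1H-pyrazol-1-yl in place of 1-ethyl-3-methyl-1H-pyrazol-5-yl on an aromatic carbon. Within the data shown here, no two measured compounds differ by exactly this change, so the size of the step is uncertain; the new ring carries neither the ethyl nor the methyl that compound 1 carries. Because compound 1 already sits at 2100 nM, the step from compound 1 to compound 4 is expected to be modest and towards weaker binding, a 1.7-fold higher number from compound 1 to compound 4 (0.22 log units; within the scatter), though an outcome within the scatter would not surprise. Compound 4 is expected to give 3500 nM, with a range from 900 nM to 14000 nM.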

Compound 4, inhibition constant: > 5800 nM
Compound 4 was reported as a limit (the forecaster's own chance of this, stated with the estimate: 15%); middle value at least 1.6-fold (0.21 log units) away from the limit.
By their numbers in this assay, from the lowest: compound 3; then compound 2; then compound 1. At a limit, above all of these: compound 4.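

In this assay compound 4 gives > 5800 nM, which is a limit of the assay and not an exact number. Among these compounds, putting 1H-pyrazol-1-yl in place of 1-ethyl-3-methyl-1H-pyrazol-5-yl on this aromatic carbon gives an at least 2.7-fold higher number from compound 1 to compound 4 (0.44 log units; beyond the scatter), the first step here that changes only one place, and it shows that a smaller ring with the same count of hydrogen-bond acceptors does not keep the binding of compound 1. Only the smallest possible size of this step can be stated, and the true size stays open: the limit of > 5800 nM in this assay, at which 1 of the 4 values shown sits.

The compounds shown leave open whether a single methyl or a single ethyl on the pyrazole would restore binding, and which of the two groups in compound 1 matters more. They also do not show what an amine or a carboxylic acid on this ring would do.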